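Ehrlich cell cytotoxicity series: from compound 3 to compound 4

The source may hold more compounds than are shown below. What is called first, only, known or untested is meant among the compounds shown, and "the series" means these compounds.

Measured so far:
compound 1 `COc1cc(N2C(N)=C(C#N)C(c3c(O)ccc4ccccc34)C3=C2CC(C)(C)CC3=O)cc(OC)c1OC` gives 15%
compound 2 `COc1cc(N2C(N)=C(C#N)C(c3ccc(OC)c4ccccc34)C3=C2CC(C)(C)CC3=O)cc(OC)c1OC` gives 40%
compound 3 `COc1cc(N2C(N)=C(C#N)C(c3ccc(O)cc3)C3=C2CC(C)(C)CC3=O)cc(OC)c1OC` gives 90%

In a functional assay on Ehrlich cells (Mus musculus) for cytotoxicity, tested at 50 ug/mL (a lower number here means a weaker effect, a higher number a stronger effect of the compound at the concentration tested), compound 3 stands highest of the three numbers, with compound 2 nearest and compound 1 furthest. Compound 4 `COc1cc(N2C(N)=C(C#N)C(/C=C/c3ccccc3)C3=C2CC(C)(C)CC3=O)cc(OC)c1OC` has not yet been measured. Its difference from compound 3: 2-phenylethenyl in place of 4-hydroxyphenyl on a saturated ring carbon.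

Among the measured compounds shown here, the steps that bear on this change are those ending at compound 3, since both also exchange the group on the saturated ring carbon: a number 75 percentage points higher from compound 1 to compound 3 (beyond the scatter) and a number 50 percentage points higher from compound 2 to compound 3 (beyond the scatter). Both show that 4-hydroxyphenyl at this place gave a far higher number than either naphthyl group. For the measured compounds named here, no measured step introduces 2-phenylethenyl, which carries no hydrogen-bond donor or acceptor, so its effect cannot be read from the series directly. Given that all other groups tried at this place gave lower numbers than compound 3, a downward step is expected for compound 4, of moderate to large size, estimated as a number 40 percentage points lower from compound 3 to compound 4 (beyond the scatter). Compound 4 is estimated at 50%, with a range of 20% to 85%.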

Compound 4, a percentage reported as activity, at one concentration (the size of the read-out at that concentration, not a potency): 30%
Compound 4: the middle estimate sits 20 percentage points above what was measured, within the range that was stated.
By their numbers in this assay, from the lowest: compound 1; then compounds 4 and 2 (each within the scatter of the next); then compound 3.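

In this assay, a single six-membered aromatic ring at this saturated ring carbon does not by itself preserve the level of compound 3, with a number 60 percentage points lower from compound 3 to compound 4 (beyond the scatter). The 2-phenylethenyl group cannot be separated from 4-methoxynaphthalen-1-yl, given a number 10 percentage points lower from compound 2 to compound 4 (within the scatter), but it does stand apart from 2-hydroxynaphthalen-1-yl, with a number 15 percentage points higher from compound 1 to compound 4 (beyond the scatter). Among the four groups at this place, 4-hydroxyphenyl remains the only one with steps beyond the scatter to all the others, and no evidence is at hand to explain this.

This change removes the hydroxyl and inserts a double bond outside the aromatic ring together, so the compounds shown cannot assign the loss to either feature. Open too, on these data alone, is how a plain phenyl, 4-methoxyphenyl or 2-phenylethyl group would read at this carbon.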